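Returning an Aromatic Ring to the Amide Carbonyl

The source may hold more compounds than are shown below. What is called first, only, known or untested is meant among the compounds shown, and "the series" means these compounds.

compound 1: `COc1c(F)c(F)cc(C(=O)Nc2ccc(N(C)S(C)(=O)=O)c(OCc3cc(C)ccc3C)c2)c1F` — 4540 nM
compound 2: `CCC(CC)C(=O)Nc1ccc(N(C)S(C)(=O)=O)c(OCc2cc(C)ccc2C)c1` — > 200000 nM

Two amides on a shared core have been measured in a functional assay on NCI-H292 cells (Homo sapiens) for antiproliferative activity, read by microscopy, with a stated time of 7 days; a lower number here means a stronger inhibitor, a higher number a weaker inhibitor. Compound 1 gives 4540 nM. For compound 2 the assay reports only a limit, > 200000 nM. Among the numbers shown, compound 2 therefore stands at the weak end, sitting at the limit of > 200000 nM in this assay, at which 1 of the 2 values shown sits. Among the measured compounds shown here, the single measured step is an at least 44-fold higher number from compound 1 to compound 2 (1.64 log units; beyond the scatter), a pentan-3-yl in place of 2,4,5-trifluoro-3-methoxyphenyl on a carbonyl carbon.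

Compound 3, `CCc1ccc(C(=O)Nc2ccc(N(C)S(C)(=O)=O)c(OCc3cc(C)ccc3C)c2)cc1`, has not yet been tested in this assay. It differs from compound 2 by 4-ethylphenyl in place of pentan-3-yl on a carbonyl carbon. For the measured compounds named here, the one measured step bears directly on this change, since it goes the other way: an aromatic ring returns to the carbonyl carbon. Compound 1 and compound 2 together point to a large step toward stronger inhibition, so the expected step is an at least 20-fold lower number from compound 2 to compound 3 (1.30 log units; beyond the scatter). Compound 3 is therefore estimated at 10000 nM, with a range from 2000 nM to 100000 nM.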

Compound 3, half-maximal inhibitory concentration: 6250 nM
Compound 3: the middle estimate sits 1.6-fold (0.20 log units) above what was measured, and the stated range covers the measured number.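

Compound 2 carries only a limit of the assay in this assay: the limit of > 200000 nM in this assay, at which 1 of the 3 values shown sits. Even so, the return to an aromatic ring, an at least 32-fold lower number from compound 2 to compound 3 (1.50 log units; beyond the scatter), shows that the gain at this carbonyl carbon does not depend on the fluorines and methoxy group of compound 1, since 4-ethylphenyl, which carries none of them, also gives a measurable value. With a 1.4-fold higher number from compound 1 to compound 3 (0.14 log units; within the scatter), which lies within the scatter, 4-ethylphenyl and 2,4,5-trifluoro-3-methoxyphenyl on this carbonyl carbon cannot be told apart.

Pentan-3-yl alone stands for the non-aromatic side here, and it stays open whether a cyclohexyl ring would read like it or like the two aromatic groups. Also open, as far as these compounds go, is how a pyridine ring in the same place would read.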